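Replacing Bromo with Methoxy: Expected Antiproliferative Potency

The source may hold more compounds than are shown below. What is called first, only, known or untested is meant among the compounds shown, and "the series" means these compounds.

Compound 1 `COc1cc(C(=O)c2sc(-c3ccc(Br)cc3)cc2N)cc(OC)c1OC` gives 150 nM in a functional assay on FM3A cells (Mus musculus) for antiproliferative activity (on this read-out higher numbers stand for weaker inhibition and lower numbers for stronger inhibition), the highest of the two numbers measured. Compound 2 `COc1cc(C(=O)c2sc(-c3ccc([N+](=O)[O-])cc3)cc2N)cc(OC)c1OC` gives 64 nM. Within the data shown here, the only measured step, a 2.3-fold lower number from compound 1 to compound 2 (0.37 log units; beyond the scatter), put nitro in place of bromo on an aromatic carbon and moved the number modestly. Compound 3 `COc1ccc(-c2cc(N)c(C(=O)c3cc(OC)c(OC)c(OC)c3)s2)cc1` differs from compound 1 by methoxy in place of bromo on an aromatic carbon. Among the measured compounds shown here, no measured step involves methoxy, so that step bears only loosely here, showing that exchanging the bromo at this place shifts the number modestly. A modest downward step, or none beyond the scatter, is expected, a 1.9-fold lower number from compound 1 to compound 3 (0.27 log units; within the scatter). Compound 3 is estimated at 80 nM, between 25 nM and 300 nM.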

Compound 3, half-maximal inhibitory concentration: 31 nM
For compound 3 the middle estimate is 2.6-fold (0.41 log units) above the measured one; the measured number falls inside the stated range.
By their numbers in this assay, from the lowest: compound 3; then compound 2; then compound 1.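

Methoxy in place of bromo gives a 4.8-fold lower number from compound 1 to compound 3 (0.68 log units; beyond the scatter) and so goes further than a swap to nitro, for methoxy in place of nitro gives a 2.1-fold lower number from compound 2 to compound 3 (0.31 log units; beyond the scatter) as well. On this ring, para to a large group, methoxy therefore gives the lowest number of the three groups, with both of its steps beyond the scatter. Nothing available explains this order. On these data alone, whether an amine, a carboxylic acid or a longer chain such as ethoxy would go lower or higher here stays open. So does whether methoxy keeps its lead elsewhere on the shared core.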